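Two mirror images and a new aryl group

This account rests on a few compounds, and the source may have more. Where it says the series, first, only, none or still open, it means among the compounds named here.

- compound 1 `CC1=NN(c2ccccc2)C(=O)[C@]12C(=O)C=CC[C@H]2c1ccccc1[N+](=O)[O-]`: 12900 nM
- compound 2 `CC1=NN(c2ccccc2)C(=O)[C@@]12C(=O)C=CC[C@@H]2c1ccccc1[N+](=O)[O-]`: 66400 nM

In a functional assay on A549 cells (Homo sapiens) for inhibition, read by MTT assay, with a stated time of 72 h (a higher number here means a weaker inhibitor, a lower number a stronger inhibitor), compound 1 holds the lower of the two numbers, at 12900 nM, which makes it the stronger inhibitor of the pair. Within the data shown here, the only measured step is a 5.1-fold higher number from compound 1 to compound 2 (0.71 log units; beyond the scatter), and it comes with the fact that compounds 1 and 2 differ only in the configuration as drawn. Compound 3 `CC1=NN(c2ccccc2)C(=O)[C@]12C(=O)C=CC[C@H]2c1cccc(C)c1` keeps the core of compound 1 but carries 3-methylphenyl in place of 2-nitrophenyl on a saturated ring carbon. Among the measured compounds shown here, no measurement yet tests a change of this group, so the mirror-image step offers only a rough sense of scale. For the measured compounds named here, a modest step toward a higher number seems likely, given that compound 1 at 12900 nM is the better of only two values. The expected change is a 1.6-fold higher number from compound 1 to compound 3 (0.19 log units; within the scatter). Compound 3 is estimated at 20000 nM, with an expected range of 6000 nM to 70000 nM.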

Compound 3, half-maximal inhibitory concentration: 13100 nM
The estimate for compound 3 lay 1.5-fold (0.18 log units) above the measured number; low and high end bracket the measured number.
By their numbers in this assay, from the lowest: compounds 1 and 3 (each within the scatter of the next); then compound 2.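

In this assay, putting 3-methylphenyl in place of 2-nitrophenyl on the saturated ring carbon gives a 1.0-fold higher number from compound 1 to compound 3 (0.01 log units; within the scatter), so the two compounds cannot be told apart. Among these compounds, this is the first information about this position: 2-nitrophenyl, with 2 hydrogen-bond acceptors, and 3-methylphenyl, with 0, give numbers within the usual scatter of each other. Nothing available here accounts for this result.

The compounds shown leave open whether the mirror image of compound 3 would show a gap like a 5.1-fold higher number from compound 1 to compound 2 (0.71 log units; beyond the scatter). Also open, as far as these compounds go, are how 2-methylphenyl or 3-nitrophenyl would read, which would separate the identity of the group from its place on the aromatic ring, and how an aromatic ring carrying an amine or a carboxylic acid would read here.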